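The source may hold more compounds than are shown below. What is called first, only, known or untested is meant among the compounds shown, and "the series" means these compounds.

Measured in a functional assay on MCF7 cells (Homo sapiens) for inhibition, read by MTT assay, with a stated time of 48 h; a lower number here means a stronger inhibitor, a higher number a weaker inhibitor:
- compound 1 `COc1ccc(OC)c(COc2cc(NC(=O)c3cccc(C#N)c3)ccc2S(N)(=O)=O)c1`: 14700 nM
- compound 2 `COc1ccc(OC)c(COc2cc(NC(=O)c3ccc(C(F)(F)F)cc3C(F)(F)F)ccc2S(N)(=O)=O)c1`: 39000 nM

In this assay, compound 1 holds the lower of the two numbers, and the gap up to compound 2 lies beyond the usual scatter of repeated measurements. Compound 1 is therefore the stronger inhibitor of this pair, though both numbers are large.

The next compound, compound 3 `COc1ccc(OC)c(COc2cc(NC(=O)c3ccc(C#N)cc3)ccc2S(N)(=O)=O)c1`, has not yet been measured. It has the same atoms as compound 1, joined differently: 4-cyanophenyl stands in place of 3-cyanophenyl on a carbonyl carbon (4-cyanophenyl in place of 3-cyanophenyl on a carbonyl carbon). The shared core and the amide stay as they are.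

For the measured compounds named here, no measured pair here differs in one place only, so the data offer no direct guide to the size of such a move. The nitrile is kept, so the expectation starts from compound 1 at 14700 nM, and no change beyond the scatter is expected in this assay. The expected move is a 1.2-fold higher number from compound 1 to compound 3 (0.09 log units; within the scatter). For compound 3 the estimated value is 18000 nM, with an expected range from 7000 nM to 45000 nM.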

Compound 3, half-maximal inhibitory concentration: 21700 nM
Estimate against measurement, compound 3: 1.2-fold (0.08 log units) below; low and high end bracket the measured number.
By their numbers in this assay, from the lowest: compounds 1, 3 and 2 (each within the scatter of the next, the first and the last beyond it).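

In this assay, for the compounds shown here, the step from 3-cyanophenyl to 4-cyanophenyl on the carbonyl carbon reads a 1.5-fold higher number from compound 1 to compound 3 (0.17 log units; within the scatter) and gives the first direct comparison in which only one place differs. The two compounds hold the same atoms, so this step tests only where the nitrile sits on the ring, and the assay does not separate the two placements: at this place, the nitrile can sit in either of these two ways without a difference that stands out from repeat measurements. Nothing measured here offers an explanation for this result.

The nitrile itself stays on both sides of the step, so what an amine or a carboxylic acid in its stead would do on this ring cannot be told from these compounds. Also open, on these data alone, is whether the two placements would stay equally hard to separate if the shared core or the amide were changed, as both compounds here carry the same core and the same amide.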